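The source may hold more compounds than are shown below. What is called first, only, known or untested is meant among the compounds shown, and "the series" means these compounds.

Measured so far in a functional assay for agonist activity at Alpha-1B adrenergic receptor (Homo sapiens); a lower number here means that less compound is needed, a higher number that more compound is needed for the effect:
- compound 1, `CSc1ccc(F)cc1NCC1=NCCN1`: 1.86 nM
- compound 2, `CS(=O)(=O)c1ccc(Cl)cc1NCC1=NCCN1`: 61.7 nM
- compound 3, `CSc1cc(F)ccc1NCC1=NCCN1`: 6.03 nM

Compound 2 carries the highest number of the three. The nearest of the others is compound 3, whose number is lower, a gap beyond the usual scatter; the furthest is compound 1, lower still, also beyond the scatter. Among the compounds with values here, compound 2 is the only one of the three with a methylsulfonyl group and the only one with a chloro substituent, and no single-change step between measured compounds separates these two features, so what each contributes on its own cannot be read from these numbers.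

Compound 4, `CS(=O)(=O)c1ccc(F)cc1NCC1=NCCN1`, is not yet measured. It differs from compound 2 in one place: fluoro in place of chloro on an aromatic carbon. Within the data shown here, no measured pair shows this exchange. Nothing in the present numbers speaks for a large shift in either direction, so the step is expected to stay within or close to the scatter of this assay, a 1.2-fold lower number from compound 2 to compound 4 (0.09 log units; within the scatter). Compound 4 is accordingly estimated at 50 nM, with a range of 15 nM to 200 nM.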

Compound 4, half-maximal effective concentration: < 100000 nM
Compound 4 ended at the assay's limit (the forecaster's own chance of this, stated with the estimate: 2%); the middle value is on the limit's open side.
By their numbers in this assay, from the lowest: compound 1; then compound 3; then compound 2.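

In this assay compound 4 gives < 100000 nM, which is a limit of the assay and not a number. The steps from compound 2 and from compound 1 to compound 4 therefore cannot be read: the limit of < 100000 nM in this assay, at which 1 of the 4 values shown sits.

Still open, from the compounds shown here alone, is how far fluoro in place of chloro, or methylsulfonyl in place of methylsulfanyl, on its own shifts the number in this assay.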